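Substituent change on the shared core: compound 3 to compound 4

This account rests on a few compounds, and the source may have more. Where it says the series, first, only, none or still open, it means among the compounds named here.

Measured compounds:
compound 1, `CC(C)c1ccc(NC(=O)N2CCN(c3ncccc3Cl)CC2)cc1`: 17.3 nM
compound 2, `CC(C)c1ccc(NC(=O)N2CCN(c3ncccc3Br)CC2)cc1`: 27.1 nM
compound 3, `Cc1cccnc1N1CCN(C(=O)Nc2ccc(C(C)C)cc2)CC1`: 173 nM

All three numbers come from a functional assay on HEK293 cells for antagonist activity at transient receptor potential cation channel subfamily V member 1 (Rattus norvegicus); on this read-out lower numbers stand for stronger inhibition and higher numbers for weaker inhibition. Compound 3 stands highest of the three: its step from compound 2 is a 6.4-fold higher number from compound 2 to compound 3 (0.81 log units; beyond the scatter) and from compound 1 is a 10-fold higher number from compound 1 to compound 3 (1.00 log units; beyond the scatter), both beyond the scatter, while a 1.6-fold higher number from compound 1 to compound 2 (0.19 log units; within the scatter) lies within it. So replacing either halogen by methyl at this position raised the number clearly.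

Compound 4, `CC(C)c1ccc(NC(=O)N2CCN(c3ncccc3C(F)F)CC2)cc1`, has not been measured. It differs from compound 3 by difluoromethyl in place of methyl on an aromatic carbon. Among the compounds with values here, no measured step covers methyl against difluoromethyl directly; the steps that bear on it are the two halogen-to-methyl steps from compound 1 and compound 2 to compound 3, which show that the substituent at this position moves the number in this assay by a modest amount. Given that compound 3 gave 173 nM, the expected step is a 3.5-fold lower number from compound 3 to compound 4 (0.54 log units; beyond the scatter), a lower number, on the order of the halogen compounds but with wide uncertainty.

Compound 4 is estimated at 50 nM in this assay, within 15 nM to 170 nM.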

Compound 4, half-maximal inhibitory concentration: 61.5 nM
For compound 4 the middle estimate is 1.2-fold (0.09 log units) below the measured one; the range from low to high includes it.
By their numbers in this assay, from the lowest: compounds 1 and 2 (each within the scatter of the next); then compound 4; then compound 3.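

In this assay difluoromethyl on this aromatic carbon gives a result that fits neither the halogens nor methyl. The step of a 2.8-fold lower number from compound 3 to compound 4 (0.45 log units; beyond the scatter) recovers only part of the ground lost with methyl, while a 2.3-fold higher number from compound 2 to compound 4 (0.36 log units; beyond the scatter) and a 3.6-fold higher number from compound 1 to compound 4 (0.55 log units; beyond the scatter) leave compound 4 short of both halogen compounds, all three steps beyond the scatter. The position therefore gives a graded order rather than a simple split between halogen and methyl, although no data shown here account for that order.

On these data alone, whether a trifluoromethyl group, a nitrile or an amine at this position would stand with compound 1 and compound 2, with compound 3 or elsewhere remains open. Also open, as far as these compounds go, is whether this order would hold with a change elsewhere on the shared core.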